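This account rests on a few compounds, and the source may have more. Where it says the series, first, only, none or still open, it means among the compounds named here.

Two amides built on a shared core have been tested in a functional assay on T-24 cells (Homo sapiens) for cytotoxicity, read by CCK-8 assay, with a stated time of 24 h; a lower number here means a stronger inhibitor, a higher number a weaker inhibitor. Compound 1, `C/C(=C\c1cc(-c2ccc(F)cc2)cs1)C(N)=O`, gives in this assay a result of > 50000 nM, which is a limit of the assay and not a number. Compound 2, `C/C(=C\c1cccc(-c2ccccc2)c1)C(N)=O`, likewise gives in this assay > 50000 nM, again a limit rather than a measured value. Compound 2 therefore stands at the same limit as compound 1, where both of the results so far sit (the limit of > 50000 nM in this assay, at which 2 of the 2 values shown sit). Compound 3, `C/C(=C\c1cccc(-c2ccc(C)cc2)c1)C(N)=O`, differs from compound 2 by methyl in place of hydrogen on an aromatic carbon, a methyl in place of hydrogen on an aromatic carbon, para to a large group. Among the measured compounds shown here, no measured step between compounds is available to guide this change, so no shift beyond the scatter of this assay is expected in either direction. Compound 3 is therefore estimated to give 50000 nM in this assay, within a range of 10000 nM to 100000 nM, which corresponds to an expected step of a number no higher from compound 2 to compound 3 (the limit leaves the size open).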

Compound 3, half-maximal inhibitory concentration: 7650 nM
Estimate against measurement, compound 3: 6.5-fold (0.82 log units) above, and the stated range ends above it.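

Methyl in place of hydrogen on an aromatic carbon, para to a large group, gives in this assay an at least 6.5-fold lower number from compound 2 to compound 3 (0.81 log units; beyond the scatter), the first step among these compounds that can be read, and one beyond the scatter. Among the compounds shown here, compound 3 is also the first compound here to give a number and not a limit, which shows that this position responds to the addition of a single carbon. The full size of the step stays open because compound 2 carries only a limit: the limit of > 50000 nM in this assay, at which 2 of the 3 values shown sit.

The compounds shown do not tell whether a longer chain such as ethyl, a methoxy group, a chlorine or an amine at this position would give a similar result. They also leave open whether the same methyl would have any such effect on the core of compound 1.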